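The compounds below may be only part of what the source reports. "The series", "measured", "known", "first", "only" and "open" are said of these compounds alone.

Measured in an in vitro ADME assay on microsomes from liver (Rattus norvegicus) for metabolic stability, read by LC-MS, tested at 1 uM; a higher number here means faster removal of the compound, a lower number slower removal:
- Compound 1 `CN(C)S(=O)(=O)c1ccc(F)c(C#Cc2cc(Cl)ccc2OCC(=O)O)c1`: < 10 mL.min-1.g-1, a limit of the assay
- Compound 2 `Cc1ccc(S(=O)(=O)NC(C)C)cc1C#Cc1cc(Cl)ccc1OCC(=O)O`: 12 mL.min-1.g-1
- Compound 3 `Cc1ccc(S(=O)(=O)N2CCOCC2)cc1C#Cc1cc(Cl)ccc1OCC(=O)O`: 10 mL.min-1.g-1

Compound 3 has one close neighbour with a real number, compound 2, and the two lie within the scatter of each other. Compound 1 gives only a limit and cannot be placed more exactly.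

The unmeasured compound 4 `Cc1ccc(S(=O)(=O)N(C)C)cc1C#Cc1cc(Cl)ccc1OCC(=O)O` differs from compound 3 in one place: dimethylamino in place of morpholin-4-yl on a sulfonyl sulfur. Here dimethylamino stands in place of morpholin-4-yl on a sulfonyl sulfur.

One measured step involves a change at this sulfur: a 1.2-fold lower number from compound 2 to compound 3 (0.08 log units; within the scatter). This single step is a thin guide, but it gives no reason to expect a shift beyond the scatter in this assay. The expected change is a 1.1-fold higher number from compound 3 to compound 4 (0.04 log units; within the scatter). For compound 4 the estimate is 11 mL.min-1.g-1, with an expected range from 7 mL.min-1.g-1 to 20 mL.min-1.g-1.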

Compound 4, intrinsic clearance in microsomes: 22 mL.min-1.g-1
The estimate for compound 4 lay 2.0-fold (0.30 log units) below the measured number; the measured number lies above the stated range.
By their numbers in this assay, from the lowest: compounds 3, 2 and 4 (each within the scatter of the next, the first and the last beyond it).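

In this assay, within the data shown here, the group on the sulfonyl sulfur can shift the number: a 2.2-fold higher number from compound 3 to compound 4 (0.34 log units; beyond the scatter) is the first step at this sulfur beyond the scatter. Dimethylamino and isopropylamino remain unresolved, with a 1.8-fold higher number from compound 2 to compound 4 (0.26 log units; within the scatter) lying within it. Methyl in place of fluoro on an aromatic carbon gives an at least 2.2-fold higher number from compound 1 to compound 4 (0.34 log units; beyond the scatter) as a step that starts from a limit, which is all compound 1 provides: the limit of < 10 mL.min-1.g-1 in this assay, at which 1 of the 4 values shown sits.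

On these data alone, it remains open where a piperidin-1-yl group on the same sulfur would fall, with its ring carbons but no ring oxygen.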